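Series notes: formyl to hydroxy on the aromatic carbon

The source may hold more compounds than are shown below. What is called first, only, known or untested is meant among the compounds shown, and "the series" means these compounds.

Within the data shown here, compound 2 `CC1(C)C=C(n2ccccc2=O)c2cc(C=O)ccc2O1` gives 6.91 in a functional assay (aorta) with Rattus norvegicus as the target (a lower number here means a less potent compound, a higher number a more potent compound, by a factor of ten per unit of this negative logarithm), the lowest of the two numbers so far; compound 1 `CC1(C)C=C(n2ccccc2=O)c2cc(C(=O)c3ccccc3F)ccc2O1` gives 7.08 in this assay, within the scatter of compound 2. Among the measured compounds shown here, the only measured step, a number 0.17 log units lower from compound 1 to compound 2 (within the scatter), stayed within the scatter. Compound 3 `CC1(C)C=C(n2ccccc2=O)c2cc(O)ccc2O1` carries hydroxy in place of formyl on an aromatic carbon. For the measured compounds named here, no measured step removes the carbonyl itself, so that step is only a weak guide. The expected change is a number 0.21 log units lower from compound 2 to compound 3 (within the scatter), a small step or none beyond the scatter. Compound 3 is estimated at 6.7, between 6 and 7.4 in this assay.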

Compound 3, logarithm of the reciprocal of the active concentration, log(1/C): 5.44
Compound 3: middle estimate off by 1.26 log units, on the high side; measured number outside the range, below it.
By their numbers in this assay, from the lowest: compound 3; then compounds 2 and 1 (each within the scatter of the next).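

In this assay, this aromatic carbon is sensitive to the change from a carbonyl-bearing group to hydroxy: hydroxy in place of formyl gives a number 1.47 log units lower from compound 2 to compound 3 (beyond the scatter), and hydroxy in place of (2-fluorophenyl)carbonyl gives a number 1.64 log units lower from compound 1 to compound 3 (beyond the scatter). The earlier exchange on the carbonyl carbon stayed within the scatter, so the large steps appear only where the carbonyl leaves. Nothing available here explains this loss.

From the compounds shown here alone, whether the step follows from losing the carbonyl or from adding hydroxy stays open. A methoxy group, an amine or a carboxylic acid on this aromatic carbon would help separate the two.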